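This account rests on a few compounds, and the source may have more. Where it says the series, first, only, none or still open, it means among the compounds named here.

In a functional assay on NCI-H1299 cells (Homo sapiens) for antiproliferative activity, read by CCK-8 assay, with a stated time of 72 h (a lower number here means a stronger inhibitor, a higher number a weaker inhibitor), three compounds built on a shared core have been measured. Compound 1 (`Nc1ccccc1NC(=O)c1ccc(CSC(=S)N2CCc3ccccc32)cc1`) gives 2900 nM, compound 2 (`Nc1ccccc1NC(=O)c1ccc(CSC(=S)N2CCc3cc(Cl)ccc32)cc1`) gives 3280 nM and compound 3 (`CC1CCCCN1C(=S)SCc1ccc(C(=O)Nc2ccccc2N)cc1`) gives 1300 nM. Compound 3 therefore has the lowest number of the three and is the strongest inhibitor among them.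

Compound 4 (`CCN(Cc1ccncc1)C(=S)SCc1ccc(C(=O)Nc2ccccc2N)cc1`) has not yet been measured. It has ethyl((pyridin-4-yl)methyl)amino in place of 2-methylpiperidin-1-yl on a thiocarbonyl carbon.

Within the data shown here, no measured step makes exactly this exchange, but two steps change the group at the same place. They are a 2.2-fold lower number from compound 1 to compound 3 (0.35 log units; beyond the scatter) and a 2.5-fold lower number from compound 2 to compound 3 (0.40 log units; beyond the scatter), and both are modest. The third step, a 1.1-fold higher number from compound 1 to compound 2 (0.05 log units; within the scatter), adds a chloro group, so it bears less directly on this exchange.

These three compounds offer only a thin basis for a forecast. Because compound 3 at 1300 nM is the lowest of the three, a new group seems more likely to give a higher number than a lower one, by a step of similar modest size. Expected in this assay is a 1.5-fold higher number from compound 3 to compound 4 (0.19 log units; within the scatter). The estimated value for compound 4 is 2000 nM, with an expected range from 700 nM to 6000 nM.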

Compound 4, half-maximal inhibitory concentration: 750 nM
Compound 4: middle estimate off by 2.7-fold (0.43 log units), on the high side, within the range that was stated.
By their numbers in this assay, from the lowest: compounds 4 and 3 (each within the scatter of the next); then compounds 1 and 2 (each within the scatter of the next).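

Replacing 2-methylpiperidin-1-yl with ethyl((pyridin-4-yl)methyl)amino gives a 1.7-fold lower number from compound 3 to compound 4 (0.24 log units; within the scatter) in this assay, so at this thiocarbonyl carbon a group with a six-membered aromatic ring and a hydrogen-bond acceptor performs on a par with the non-aromatic ring. Measured against the 2,3-dihydro-1H-indol-1-yl group, the same new group gives a 3.9-fold lower number from compound 1 to compound 4 (0.59 log units; beyond the scatter) and, against 5-chloro-2,3-dihydro-1H-indol-1-yl, it gives a 4.4-fold lower number from compound 2 to compound 4 (0.64 log units; beyond the scatter) in this assay. Two quite different groups, in compound 3 and compound 4, therefore both give lower numbers than the two groups in compound 1 and compound 2, which shows that this position accepts more than one kind of ring and that a non-aromatic ring is not required.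

Still open, going by these compounds, is which part of the new group counts: a benzyl in place of the (pyridin-4-yl)methyl part, a propyl chain in place of the ethyl, or a morpholin-4-yl ring in place of the whole group would each help to separate these parts. Nothing in the data gives a reason for the differences seen at this position.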